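The source may report more compounds than this note shows. Statements on the series, on what has been measured and on what is new or still open speak of the compounds shown alone.

Measured so far:
Compound 1 `c1nnc2nnc(N3CCCC3)nn12`: in a functional assay on MCF7 cells (Homo sapiens) for inhibition, read by MTT assay, with a stated time of 72 h (on this read-out higher numbers stand for weaker inhibition and lower numbers for stronger inhibition), compound 1 gives 5130 nM.
Compound 2 `CC(Nc1nnc2nncn2n1)C(=O)O`: compound 2 gives > 100000 nM, which is a limit of the assay and not a number.
Compound 3 `CCCCC(=O)N1CCN(c2nnc3nncn3n2)CC1`: compound 3 gives 2760 nM.

Compound 3 and compound 1 give numbers that sit within the usual scatter of each other, so neither stands apart from the other. Compound 2 gives only a limit. The step to compound 4 `CCC(=O)N1CCN(c2nnc3nncn3n2)CC1` changes one place: hydrogen in place of ethyl on a saturated chain carbon, two bonds along the chain from a carbonyl carbon. Among the measured compounds shown here, no measured pair here differs in a single place, so the size of such a step is not known from these compounds. Shortening the chain in this way is a modest change, and the expected step in this assay from compound 3 to compound 4 is a 1.3-fold higher number from compound 3 to compound 4 (0.10 log units; within the scatter), not beyond the scatter. Compound 4 is therefore estimated at about 3500 nM, most likely between 1500 nM and 9000 nM.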

Compound 4, half-maximal inhibitory concentration: 14800 nM
Compound 4: middle estimate off by 4.2-fold (0.63 log units), on the low side, outside the stated range (above it).
By their numbers in this assay, from the lowest: compounds 3 and 1 (each within the scatter of the next); then compound 4. At a limit, above all of these: compound 2.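

Replacing ethyl with hydrogen on a saturated chain carbon, two bonds along the chain from a carbonyl carbon, gives in this assay a 5.4-fold higher number from compound 3 to compound 4 (0.73 log units; beyond the scatter). Among the compounds shown here, this is the first step here between compounds that differ in one place, and it shows that the change from butylcarbonyl to propanoyl alone moves the number beyond the scatter. The outer part of this chain therefore matters in this assay.

As far as these compounds go, whether a longer chain, an amine or a carboxylic acid at this place would lower or raise the number stays open. Nothing measured here accounts for the size of this step.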